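A Shorter Chain and Expected Cell Tolerance

The compounds below may be only part of what the source reports. "The series", "measured", "known", "first", "only" and "open" are said of these compounds alone.

Compound 1 `O=C(NCc1ccccc1)c1nccnc1Cl`: "not determined" (no result reported)
Compound 2 `CCCCCCCNc1nccnc1C(=O)NCc1ccccc1`: 100000 nM

In an ADME assay on MDCK cells (Canis lupus familiaris) for cytotoxicity, read by microscopy, with a stated time of 6 days (a higher number here means that more compound is tolerated, a lower number that less compound is tolerated), compound 2 gives 100000 nM, the only number shown; compound 1 carries no result in this assay. Compound 3 `CCCCCNc1nccnc1C(=O)NCc1ccccc1` is the compound still to be measured, and it differs from compound 2 in one place: hydrogen in place of ethyl on a saturated chain carbon, five bonds along the chain from a nitrogen on an aromatic ring. Within the data shown here, no step between two measured compounds is available to show how this assay responds to such a change, so any expectation rests on compound 2 alone. The step from compound 2 to compound 3 is expected to be small, no larger than the usual scatter, in no firm direction, giving no change at the digits printed from compound 2 to compound 3 (within the scatter). Compound 3 is therefore estimated at 100000 nM, within a range from 50000 nM to 200000 nM.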

Compound 3, minimum cytotoxic concentration: >= 20000 nM
Compound 3: only a limit was reported; the forecaster's own chance of this, stated with the estimate: 30%; the middle value lies beyond the limit too.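

In this assay, among these compounds, compound 3 gives >= 20000 nM, which is a limit and not a number, so no step from compound 2 to compound 3 can be read. The compounds shown leave open whether hydrogen in place of ethyl on this chain changes how much compound the cells tolerate.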